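Bromo for methyl on the anilide ring of compound 2

A few compounds are considered here, and "the series" means these few. Any claim that something is new, unique, unknown or untested is made for them only; others in the source may bear on it.

Compound 1 `O=C(Nc1ccccc1)c1nc(=O)[nH]c2ccccc12` and compound 2 `Cc1ccc(NC(=O)c2nc(=O)[nH]c3ccccc23)cc1` share one core and differ only at one aromatic carbon. In an assay on CHO cells for displacement of a labelled ligand from adenosine receptor A3 (Homo sapiens) (a lower number here means a stronger inhibitor, a higher number a weaker inhibitor), compound 1 gives 50 nM, and compound 2 gives 26.7 nM. For the measured compounds named here, the step of a 1.9-fold lower number from compound 1 to compound 2 (0.27 log units; within the scatter) shows that these two values cannot be told apart, so compound 2 stands level with compound 1 on the numbers so far.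

Compound 3 `O=C(Nc1ccc(Br)cc1)c1nc(=O)[nH]c2ccccc12` is the next step: bromo in place of methyl on an aromatic carbon. Going by the values given here, the only measured step at this position, a 1.9-fold lower number from compound 1 to compound 2 (0.27 log units; within the scatter), stayed inside the scatter, and nothing measured here separates bromo from methyl. A step of no clear size in either direction is therefore expected, written as a 1.1-fold lower number from compound 2 to compound 3 (0.03 log units; within the scatter).

For compound 3 the estimate in this assay is 25 nM, expected to fall between 9 nM and 70 nM.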

Compound 3, inhibition constant: 27.2 nM
Estimate against measurement, compound 3: 1.1-fold (0.04 log units) below; measured number inside the range.
By their numbers in this assay, from the lowest: compounds 2, 3 and 1 (each within the scatter of the next).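

Placing bromo where methyl stood, on the aromatic carbon para to a large group, gives a 1.0-fold higher number from compound 2 to compound 3 (0.01 log units; within the scatter) in this assay and so leaves no measurable difference between these two groups. Bromo set against plain hydrogen gives a 1.8-fold lower number from compound 1 to compound 3 (0.26 log units; within the scatter) and likewise stays inside the usual spread of repeat measurements, so the second substituent tried here, like the first, does not separate from the unsubstituted ring on these numbers. No supporting measurement is available to explain this result.

From the compounds shown here alone, whether an amine, a carboxylic acid or a longer chain such as butyl at this same carbon would produce a step beyond the scatter remains open. Also open, going by these compounds, is whether methyl and bromo would still match on a different carbon of this ring.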